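A few compounds are considered here, and "the series" means these few. Any claim that something is new, unique, unknown or untested is made for them only; others in the source may bear on it.

Notes on the series. Compound 1 `COc1cc2c(Oc3ccc(NC(=O)c4nn(-c5cccc(F)c5)c(=O)cc4C)cc3F)ccnc2cc1OCCCN1CCC(C)CC1` gives 140 nM in a functional assay on MKN-45 cells (Homo sapiens) for inhibition, read by MTT assay, with a stated time of 72 h; on this read-out lower numbers stand for stronger inhibition and higher numbers for weaker inhibition. Compound 2 `COc1ccc(-n2nc(C(=O)Nc3ccc(Oc4ccnc5cc(OCCCN6CCCC6)c(OC)cc45)c(F)c3)c(C)cc2=O)cc1` gives 1290 nM in this assay, and compound 3 `COc1ccc(-n2nc(C(=O)Nc3ccc(Oc4ccnc5cc(OCCCN6CCCCC6)c(OC)cc45)c(F)c3)c(C)cc2=O)cc1` gives 330 nM in this assay. For the measured compounds named here, the one single-point step measured so far, a 3.9-fold lower number from compound 2 to compound 3 (0.59 log units; beyond the scatter), concerns the same amine end of the chain. On these three numbers compound 3 stands second highest, above compound 1 and below compound 2.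

Compound 4 `COc1ccc(-n2nc(C(=O)Nc3ccc(Oc4ccnc5cc(OCCCN6CCC(C)CC6)c(OC)cc45)c(F)c3)c(C)cc2=O)cc1` differs from compound 3 by methyl in place of hydrogen on a saturated ring carbon. Going by the values given here, no measured step covers this exact change; compound 1 carries the same 4-methylpiperidin-1-yl group but also differs from compound 3 elsewhere, so its value is only a pointer. A small lowering in this assay is expected, near the edge of the scatter, a 1.5-fold lower number from compound 3 to compound 4 (0.18 log units; within the scatter). Compound 4 is therefore estimated at 220 nM, range 100 nM to 500 nM.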

Compound 4, half-maximal inhibitory concentration: 400 nM
Beside the measured number, compound 4's estimate is 1.8-fold (0.26 log units) below it; low and high end bracket the measured number.
By their numbers in this assay, from the lowest: compound 1; then compounds 3 and 4 (each within the scatter of the next); then compound 2.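

In this assay, methyl on the saturated ring carbon three ring bonds from the ring nitrogen changes nothing beyond the scatter (a 1.2-fold higher number from compound 3 to compound 4 (0.08 log units; within the scatter)), so this position tolerates the added carbon without a readable gain. The 4-methylpiperidin-1-yl group still stands apart from pyrrolidin-1-yl (a 3.2-fold lower number from compound 2 to compound 4 (0.51 log units; beyond the scatter)), and with the amine end held constant, 4-methoxyphenyl in place of 3-fluorophenyl on the aromatic nitrogen gives its own step (a 2.9-fold higher number from compound 1 to compound 4 (0.46 log units; beyond the scatter)). No evidence at hand accounts for these numbers.

Open, as far as these compounds go, is whether a morpholine at the chain end, or a longer chain carrying the same amine, would keep this level.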